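Oxanyl for Methoxypropyl: Clearance Expectation for Compound 4

The compounds below may be only part of what the source reports. "The series", "measured", "known", "first", "only" and "open" are said of these compounds alone.

Compound 1 `COCCOCCCCc1[nH]c2ccccc2c(=O)c1C` and compound 2 `COC(C)(C)CCOc1cccc(OCc2[nH]c3ccccc3c(=O)c2C)c1` were both run in an in vitro ADME assay on microsomes from liver (Mus musculus) for metabolic stability, tested at 0.2 uM; on this read-out lower numbers stand for slow clearance and higher numbers for fast clearance. Compound 1 reaches only a limit of > 1000 mL/min/kg. Compound 2 likewise reaches only a limit of > 1000 mL/min/kg. Compound 3 `Cc1c(COc2cncc(OCCC(C)(C)O)c2)[nH]c2ccccc2c1=O` gives 225 mL/min/kg. Compound 2 thus stands at the limit of > 1000 mL/min/kg in this assay, at which 2 of the 3 values shown sit. Compound 4 `Cc1c(COc2cccc(OCC3CCOCC3)c2)[nH]c2ccccc2c1=O` has not been measured; it differs from compound 2 in one place: oxan-4-yl in place of 2-methoxy-2-methylpropyl on a saturated chain carbon bound to an oxygen on an aromatic ring. Among the measured compounds shown here, with compound 2 at a limit, no step between measured compounds is known, so the size of this change in this assay cannot be read from the data; a move downward out of the limit is possible but not assured. For compound 4 an estimated value of 650 mL/min/kg is expected, with a range from 250 mL/min/kg to 1200 mL/min/kg. That amounts to an expected step of an at least 1.5-fold lower number from compound 2 to compound 4 (0.18 log units; that floor lies within the scatter).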

Compound 4, clearance: 420 mL/min/kg
For compound 4 the middle estimate is 1.5-fold (0.19 log units) above the measured one, and the stated range covers the measured number.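

In this assay, oxan-4-yl in place of 2-methoxy-2-methylpropyl on a saturated chain carbon bound to an oxygen on an aromatic ring gives an at least 2.3-fold lower number from compound 2 to compound 4 (0.37 log units; beyond the scatter). This position therefore responds to the change, even though both groups have the same heavy-atom count and only oxan-4-yl holds a ring. The step remains a floor because compound 2 has only a limit: the limit of > 1000 mL/min/kg in this assay, at which 2 of the 4 values shown sit.

As far as these compounds go, how far the step really reaches remains open. So does whether an amine or a carboxylic acid at this position would give a lower number still.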